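Ethyl for Methyl on the Amide Nitrogen: Expecting Compound 4

The compounds below may be only part of what the source reports. "The series", "measured", "known", "first", "only" and "open" are said of these compounds alone.

Measured compounds:
compound 1, `CN(C(=O)c1c(O)c2c(C(F)(F)F)cccc2n(C)c1=O)c1ccccc1`: 99%
compound 2, `CCN(C(=O)c1c(O)c2c(C(F)(F)F)cccc2n(C)c1=O)c1ccccc1`: 80%
compound 3, `CSc1cccc2c1c(O)c(C(=O)N(C)c1ccccc1)c(=O)n2C`: 100%

All three were tested in a functional assay on the whole organism for inhibition, with Mus musculus as the target, at a dose of 1 mg/kg by the oral route; on this read-out higher numbers stand for more inhibition at the one dose given (going by the name of the read-out) and lower numbers for less inhibition. Compound 1 and compound 3 share the same core apart from one group: the counted difference is methylsulfanyl in place of trifluoromethyl on an aromatic carbon. This swap made a step of a number 1 percentage points higher from compound 1 to compound 3 (within the scatter), so the two compounds read alike in this assay. Compound 2 keeps the core of compound 1 but carries the change (methyl in place of hydrogen on a saturated chain carbon bound to an amide-type nitrogen); that step came to a number 19 percentage points lower from compound 1 to compound 2 (beyond the scatter), a drop that lies outside the usual spread of repeats.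

Compound 4, `CCN(C(=O)c1c(O)c2c(SC)cccc2n(C)c1=O)c1ccccc1`, has not yet been measured. It stands to compound 3 as compound 2 stands to compound 1: the counted difference is methyl in place of hydrogen on a saturated chain carbon bound to an amide-type nitrogen, the same kind of change at the same kind of place. Among the four compounds this change occurs twice, and only the first instance has a measured outcome.

The expectation for compound 4 rests on that one earlier step. Since compound 3 and compound 1 read alike in this assay, the change in compound 4 is expected to cost about as much as it did from compound 1 to compound 2, giving an expected step of a number 19 percentage points lower from compound 3 to compound 4 (beyond the scatter). Compound 4 is therefore expected to show 81% in this assay, with a range from 62% to 95% to allow for scatter and for the fact that a single precedent carries limited weight.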

Compound 4, a percentage reported as inhibition, in the whole organism at one dose (the size of the read-out at that dose, not a potency): 73%
The estimate for compound 4 lay 8 percentage points above the measured number; measured number inside the range.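

In this assay, for the compounds shown here, methyl in place of hydrogen on a saturated chain carbon bound to an amide-type nitrogen gave a step of a number 27 percentage points lower from compound 3 to compound 4 (beyond the scatter), and this loss carried over from one core to the other without a difference that can be told from scatter: the same change on two cores in this assay, a number 19 percentage points lower (beyond the scatter) from compound 1 to compound 2 and a number 27 percentage points lower (beyond the scatter) from compound 3 to compound 4, 8 percentage points apart, within the scatter of two such steps The second swap, methylsulfanyl in place of trifluoromethyl on an aromatic carbon, gave a step of a number 7 percentage points lower from compound 2 to compound 4 (within the scatter), so it made no clear difference with either amide substituent: the same change on two cores in this assay, a number 1 percentage points higher (within the scatter) from compound 1 to compound 3 and a number 7 percentage points lower (within the scatter) from compound 2 to compound 4, 8 percentage points apart, within the scatter of two such steps This supports treating the two changes as roughly independent in these four compounds, but it rests on only two pairs for each change, comes from one read-out at one dose rather than from a potency, and does not show why the methyl-to-ethyl change lowers the number or whether it would do so on another core.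

The compounds shown leave open how a propyl chain or a benzyl group would read in place of the ethyl group. They also leave open whether a methoxy group or a chlorine atom on that aromatic carbon would match trifluoromethyl and methylsulfanyl.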